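The source may hold more compounds than are shown below. What is called first, only, known or untested is meant among the compounds shown, and "the series" means these compounds.

Going by the values given here, in a functional assay on A549 cells (Homo sapiens) for inhibition, read by MTT assay, with a stated time of 72 h (on this read-out higher numbers stand for weaker inhibition and lower numbers for stronger inhibition), compound 1 `O=C1/C(=C\c2ccccc2)c2c(ncn2COCc2ccccc2)CCN1Cc1ccccc1` gives 9900 nM and compound 2 `Cc1cccc(CN2CCc3ncn(COCc4ccccc4)c3/C(=C/c3ccccc3)C2=O)c1` gives 16100 nM so the two values lie within the scatter of each other, and compound 2 stands level with compound 1 on the only two numbers in hand. The change from compound 2 to compound 3 `CC(C)(C)c1ccc(CN2CCc3ncn(COCc4ccccc4)c3/C(=C/c3ccccc3)C2=O)cc1` reads 4-(tert-butyl)phenyl in place of 3-methylphenyl on a saturated chain carbon bound to an amide-type nitrogen in a ring and amounts to 4-(tert-butyl)phenyl in place of 3-methylphenyl on a saturated chain carbon bound to an amide-type nitrogen in a ring. Among the compounds with values here, the only measured step bearing on it is a 1.6-fold higher number from compound 1 to compound 2 (0.21 log units; within the scatter) with methyl in place of hydrogen on an aromatic carbon. Within the data shown here, no measured compound carries 4-(tert-butyl)phenyl, so the data give no direction, and no shift beyond the scatter is expected in this assay for now. The estimated step is a 1.2-fold lower number from compound 2 to compound 3 (0.06 log units; within the scatter) as a working expectation. Compound 3 is expected at 14000 nM with an estimated range from 5500 nM to 35000 nM on present data.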

Compound 3, half-maximal inhibitory concentration: 20600 nM
For compound 3 the middle estimate is 1.5-fold (0.17 log units) below the measured one, within the range that was stated.
By their numbers in this assay, from the lowest: compounds 1, 2 and 3 (each within the scatter of the next, the first and the last beyond it).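

In this assay, the exchange at this place, on a saturated chain carbon bound to an amide-type nitrogen in a ring, gives a 1.3-fold higher number from compound 2 to compound 3 (0.11 log units; within the scatter), so going from 7 to 10 heavy atoms in the entering group does not separate compound 3 from compound 2. Set against the plain benzyl of compound 1, however, the 4-(tert-butyl)phenyl group gives a 2.1-fold higher number from compound 1 to compound 3 (0.32 log units; beyond the scatter), the first step in the series to pass the scatter, though only modestly, and it runs towards weaker inhibition. No evidence is at hand that accounts for this step.

Open, as far as these compounds go, is how an amine or a carboxylic acid on this aromatic ring would read in place of these all-carbon groups. Also open, from the compounds shown here alone, is whether a phenethyl group in place of the benzyl would bring clearly stronger inhibition than compound 1, which gives 9900 nM.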